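From 4-methoxyphenyl to 2-fluorophenyl on a shared core

This account rests on a few compounds, and the source may have more. Where it says the series, first, only, none or still open, it means among the compounds named here.

Compound 1 `CC1=CC[C@H]2[C@H](CC[C@]2(C)O)C(C)(C)[C@@H]1CC[C@H]1[C@]2(C)CC[C@H](OC(=O)c3ccncc3)C(C)(C)O[C@H]2CC[C@@]1(C)O`, compound 2 `CC1=CC[C@H]2[C@H](CC[C@]2(C)O)C(C)(C)[C@@H]1CC[C@H]1[C@]2(C)CC[C@H](OC(=O)c3ccc(C)cc3)C(C)(C)O[C@H]2CC[C@@]1(C)O` and compound 3 `COc1ccc(C(=O)O[C@H]2CC[C@]3(C)[C@H](CC[C@@](C)(O)[C@H]3CC[C@@H]3C(C)=CC[C@H]4[C@H](CC[C@]4(C)O)C3(C)C)OC2(C)C)cc1` share one core and differ only in the group on a carbonyl carbon. In a functional assay on MCF7 cells (Homo sapiens) for antiproliferative activity, read by MTT assay, with a stated time of 72 h (a higher number here means a weaker inhibitor, a lower number a stronger inhibitor), compound 1 gives 25300 nM and compound 3 gives 41700 nM. Among the measured compounds shown here, these two are separated by a 1.6-fold higher number from compound 1 to compound 3 (0.22 log units; within the scatter), so compound 3 stands level with compound 1, the only other compound with an exact number. Compound 2 reaches only a limit of the assay, > 50000 nM. The steps that involve it, an at least 1.9-fold higher number from compound 1 to compound 2 (0.29 log units; that floor lies within the scatter) and an at least 1.1-fold lower number from compound 2 to compound 3 (0.07 log units; that floor lies within the scatter), are floors and do not leave the scatter.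

Compound 4 `CC1=CC[C@H]2[C@H](CC[C@]2(C)O)C(C)(C)[C@@H]1CC[C@H]1[C@]2(C)CC[C@H](OC(=O)c3ccccc3F)C(C)(C)O[C@H]2CC[C@@]1(C)O` carries 2-fluorophenyl in place of 4-methoxyphenyl on a carbonyl carbon. For the measured compounds named here, no measured step introduces this group, so the only guide is the three exchanges among pyridin-4-yl, 4-methylphenyl and 4-methoxyphenyl at the same place. None of those three goes beyond the scatter, and the step to compound 3 from compound 1 is the one measured in full. No step beyond the scatter is therefore expected in this assay, and no firm direction can be given. The expected change is a 1.2-fold lower number from compound 3 to compound 4 (0.08 log units; within the scatter). Compound 4 is expected at an estimated 35000 nM, within a range of 16000 nM to 50000 nM.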

Compound 4, half-maximal inhibitory concentration: 11300 nM
Beside the measured number, compound 4's estimate is 3.1-fold (0.49 log units) above it; the measured number lies below the stated range.
By their numbers in this assay, from the lowest: compound 4; then compounds 1 and 3 (each within the scatter of the next). At a limit, above all of these: compound 2.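

In this assay this position now shows a change that leaves the scatter: the exchanges among pyridin-4-yl, 4-methylphenyl and 4-methoxyphenyl all stayed within it, whereas 2-fluorophenyl gives a 3.7-fold lower number from compound 3 to compound 4 (0.57 log units; beyond the scatter) and a 2.2-fold lower number from compound 1 to compound 4 (0.35 log units; beyond the scatter) on the same carbonyl carbon. Compound 4 thus has the lowest number of the four, and its steps to the two compounds with exact numbers show that the group on this carbonyl carbon can move the result on the shared core. Compound 2 stands at a limit of the assay, so an at least 4.4-fold lower number from compound 2 to compound 4 (0.64 log units; beyond the scatter) is only a floor and its full size cannot be read: the limit of > 50000 nM in this assay, at which 1 of the 4 values shown sits.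

The compounds shown do not tell whether the fluorine itself carries this step, for an unsubstituted phenyl does not stand among them to compare with compound 4. Also open, on these data alone, is what an amine or a longer chain would do on this carbonyl carbon, in place of the aromatic groups seen so far.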